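Removing one chloro group from the core of compound 1

This account rests on a few compounds, and the source may have more. Where it says the series, first, only, none or still open, it means among the compounds named here.

Compound 1 `ClCc1ccc(Cn2cnc3nc(Cl)nc(Cl)c32)cc1` gives 5750 nM in a functional assay on U-251 cells (Homo sapiens) for cytotoxicity, read by sulforhodamine B assay, with a stated time of 48 h (on this read-out higher numbers stand for lower toxicity in this test and lower numbers for higher toxicity in this test), the lower of the two numbers recorded, though compound 2 `Nc1nc(Cl)c2ncn(Cc3cccc(CCl)c3)c2n1`, which gives 9330 nM, lies within the scatter of it. Compound 3 `ClCc1ccc(Cn2cnc3ncnc(Cl)c32)cc1` differs from compound 1 by hydrogen in place of chloro on an aromatic carbon. Within the data shown here, no pair of measured compounds shows this change, so the account rests on compound 1 alone. Only a small step toward a higher number is expected, a 1.4-fold higher number from compound 1 to compound 3 (0.14 log units; within the scatter). Compound 3 is estimated at 8000 nM in this assay, within a range of 3500 nM to 18000 nM.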

Compound 3, concentration lethal to 50% of the cells: 4780 nM
The estimate for compound 3 lay 1.7-fold (0.22 log units) above the measured number; measured number inside the range.
By their numbers in this assay, from the lowest: compounds 3, 1 and 2 (each within the scatter of the next).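

In this assay, the chloro group on the aromatic carbon between two ring nitrogen atoms gives way to hydrogen with a 1.2-fold lower number from compound 1 to compound 3 (0.08 log units; within the scatter), so this single change leaves the number within the scatter. The other chloro group on that ring stays in both compounds, so this result concerns one position only. Nothing at hand explains this outcome.

On these data alone, whether a methoxy group or a nitrile on this same carbon would also leave the number within the scatter remains open. So does the effect of replacing the remaining chloro group with hydrogen.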